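This account rests on a few compounds, and the source may have more. Where it says the series, first, only, none or still open, it means among the compounds named here.

Measured compounds:
- compound 1 `Cc1ccc(C(=O)NC2CCCCCC2)c(=O)n1Cc1ccc(F)cc1` in an assay on HEK293 cells for inhibition of Lysophosphatidylserine lipase ABHD12 (Homo sapiens), read by scintillation counting, with stated times of 30 min and 5 min (a higher number here means a weaker inhibitor, a lower number a stronger inhibitor), gives > 10000 nM, a limit of the assay.
- compound 2 `Cc1c(Br)cc(C(=O)NC2CCCCCC2)c(=O)n1Cc1ccc(F)cc1` in this assay gives > 10000 nM, a limit of the assay.
- compound 3 `COc1ccc(-c2cc(C(=O)NC3CCCCCC3)c(OCc3ccc(F)cc3)nc2C)cc1` in this assay gives > 10000 nM, a limit of the assay.

Compound 3 thus stands at the limit, with no number to place it against the others; every value shown sits there, as the limit of > 10000 nM in this assay, at which 3 of the 3 values shown sit, records. Among the compounds with values here, the one step within the set, a step that the two limits leave unreadable from compound 1 to compound 2, runs between two limits and its size cannot be read.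

Compound 4 `Cc1nc(OCc2ccc(F)cc2)c(C(=O)NC2CCCCCC2)cc1Br` differs from compound 3 by bromo in place of 4-methoxyphenyl on an aromatic carbon. Within the data shown here, the only measured step that touches a bromo entering on an aromatic carbon is the one from compound 1 to compound 2, and it gives no size. Nothing in the series therefore says whether this change moves potency in this assay at all; the expectation is that compound 4 stays where compound 3 stands, most likely again reported as a limit.

The estimated step that the limit leaves unreadable from compound 3 to compound 4 is expected to be none beyond the scatter. Compound 4 is estimated at 15000 nM, between 4000 nM and 50000 nM.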

Compound 4, half-maximal inhibitory concentration: 2100 nM
Estimate against measurement, compound 4: 7.1-fold (0.85 log units) above; the measured number lies below the stated range.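

In this assay, within the data shown here, the aromatic carbon para to the (4-fluorobenzyl)oxy group and ortho to the methyl group is the first place where a change gives a readable result: bromo in place of 4-methoxyphenyl gives an at least 4.7-fold lower number from compound 3 to compound 4 (0.67 log units; beyond the scatter). Among these compounds, at this place, then, the 4-methoxyphenyl group is not needed for a measurable number, and the single bromine atom brings compound 4 off the limit. The step has only a lower bound, because compound 3 is a limit of the assay and not a number: the limit of > 10000 nM in this assay, at which 3 of the 4 values shown sit.

The other step in the series cannot be read, so the compounds shown do not separate a gain from bromo itself from a gain on losing 4-methoxyphenyl. On these data alone, whether chloro, a nitrile or an unsubstituted phenyl at this place would hold, improve or lose this potency remains open.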